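The source may hold more compounds than are shown below. What is called first, only, known or untested is meant among the compounds shown, and "the series" means these compounds.

Of the compounds shown here, three of one series have been measured and a fourth has not. Compound 1 `COc1ccc(-c2c(C)oc3c(N4CC[C@@H](NC(C)=O)C4)cc(C)nc23)cc1OC`, compound 2 `CC(=O)N[C@@H]1CCN(c2cc(C)nn3c(-c4ccc5cc[nH]c5c4)c(C)nc23)C1` and compound 3 `COc1ccc(-c2c(C)nc3c(N4CC[C@@H](NC(=O)c5ccccc5)C4)cc(C)nn23)cc1OC` were tested in an ADME assay on microsomes from liver (Homo sapiens) for metabolic stability, read by LC-MS, with NADPH named in the record, with a stated time of 60 min, tested at 1 uM, in the absence of a further agent (a lower number here means that less of the compound is left, a higher number that more of the compound is left), while compound 4 `COc1ccc(-c2c(C)nc3c(N4CC[C@@H](NS(=O)(=O)c5ccc(Cl)cc5)C4)cc(C)nn23)cc1OC` awaits testing. In this assay compound 1 gives > 95%, which is a limit of the assay and not a number. Compound 2 likewise reaches the limit of > 95% in this assay. Compound 3 also stands at a limit, with > 95% in this assay. The three measured values therefore tell the same thing: the limit of > 95% in this assay, at which 3 of the 3 values shown sit. For the measured compounds named here, no step between measured compounds can be read from these limits. Compound 4 differs from compound 3 by (4-chlorophenyl)sulfonyl in place of benzoyl on an amine nitrogen. Because compound 3 sits at > 95% in this assay, the step of a number at least 5 percentage points lower from compound 3 to compound 4 (that floor lies within the scatter) is expected to be small, either none beyond the scatter or a modest fall. Compound 4 is accordingly estimated at 90% in this assay, within a range from 72% to 100%.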

Compound 4, percent of the compound remaining: > 95%
Compound 4: a limit, no number; the forecaster's own chance of this, stated with the estimate: 60%; middle value at least 5 percentage points from the limit.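

In this assay compound 4 gives > 95%, a limit of the assay and not a number. For the compounds shown here, compound 3 stands at a limit too, so no step from compound 3 to compound 4 can be read. The compounds shown leave open how any of them ranks against another, since all share one limit: the limit of > 95% in this assay, at which 4 of the 4 values shown sit.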